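Lengthening the Amine Chain: From Isobutyl to Pentyl

The source may hold more compounds than are shown below. What is called first, only, known or untested is meant among the compounds shown, and "the series" means these compounds.

Compound 1, `CS(=O)(=O)NCCN1CCC(CNC(=O)c2cccc3[nH]cnc23)CC1`, gives 11.5 nM in an assay on membranes from striatum with 5-hydroxytryptamine receptor 4 (Rattus norvegicus) as the target; on this read-out lower numbers stand for stronger inhibition and higher numbers for weaker inhibition.
Compound 2, `CS(=O)(=O)NCCN1CCC(CNC(=O)c2cc(Cl)cc3[nH]cnc23)CC1`, gives 0.11 nM in this assay.
Compound 3, `CC(C)CN1CCC(CNC(=O)c2cc(Cl)cc3[nH]cnc23)CC1`, gives 0.288 nM in this assay.

Among these three, compound 3 holds the second-lowest number: compound 2 sits nearest to it, with a 2.6-fold higher number from compound 2 to compound 3 (0.42 log units; beyond the scatter) separating the two, while compound 1 lies furthest away. The largest step in the set is a 100-fold lower number from compound 1 to compound 2 (2.02 log units; beyond the scatter), which concerns the aromatic ring and not the part of the molecule that changes next.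

Compound 4, `CCCCCN1CCC(CNC(=O)c2cc(Cl)cc3[nH]cnc23)CC1`, differs from compound 3 by butyl in place of isopropyl on a saturated chain carbon bound to an amine nitrogen in a ring. Neither measured step tests this kind of change directly. The step from compound 2 to compound 3 replaced a chain bearing a methanesulfonamido group with a plain isobutyl chain and was modest; the step from compound 1 to compound 2 does not touch the amine substituent at all. Swapping one plain hydrocarbon chain for a slightly longer plain hydrocarbon chain therefore has no measured precedent here, and the expectation is a step in this assay that stays within the scatter, with no clear direction. Compound 4 is expected to give about 0.3 nM, within a range from 0.1 nM to 0.9 nM, which corresponds to an expected step of a 1.0-fold higher number from compound 3 to compound 4 (0.02 log units; within the scatter).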

Compound 4, inhibition constant: 0.537 nM
Beside the measured number, compound 4's estimate is 1.8-fold (0.25 log units) below it; low and high end bracket the measured number.
By their numbers in this assay, from the lowest: compound 2; then compounds 3 and 4 (each within the scatter of the next); then compound 1.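

Swapping one plain hydrocarbon chain for another on the ring amine nitrogen, isobutyl for pentyl, gives a 1.9-fold higher number from compound 3 to compound 4 (0.27 log units; within the scatter) in this assay, so these two chains cannot be told apart here and this position accepts the longer pentyl chain without a measurable loss. Set against the chain carrying the methanesulfonamido group, the pentyl chain gives a 4.9-fold higher number from compound 2 to compound 4 (0.69 log units; beyond the scatter), a modest step of the same direction as a 2.6-fold higher number from compound 2 to compound 3 (0.42 log units; beyond the scatter), which shows that both plain chains read somewhat weaker than that chain while remaining far from the size of the step that chloro produced, a 100-fold lower number from compound 1 to compound 2 (2.02 log units; beyond the scatter). Nothing measured here accounts for these small differences.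

The compounds shown leave open whether a longer chain such as octyl, or a chain ending in a hydroxyl group or a carboxylic acid, would keep the number this low. They also leave open whether the large gain seen with chloro carries over when the amine nitrogen bears pentyl and not the chain with the methanesulfonamido group.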